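Methoxy for trifluoromethyl near the tolerance limit

The compounds below may be only part of what the source reports. "The series", "measured", "known", "first", "only" and "open" are said of these compounds alone.

Among the measured compounds shown here, in an ADME assay on BHK cells (Mesocricetus auratus) for cytotoxicity, read by MTT assay (a higher number here means that more compound is tolerated, a lower number that less compound is tolerated), compound 2 (`OC[C@@H]1[C@@H](O)[C@H](O)[C@@H](O)CN1CCCCCCOc1ccc(C(F)(F)F)cc1`) gives 470000 nM as the only actual number so far. Compound 1 (`OC[C@@H]1[C@@H](O)[C@H](O)[C@@H](O)CN1CCCCCCOc1ccc(OC(F)(F)F)cc1`) stands at > 500000 nM and that is a limit of the assay, not a number.

Compound 3 (`COc1ccc(OCCCCCCN2C[C@H](O)[C@@H](O)[C@H](O)[C@H]2CO)cc1`) carries methoxy in place of trifluoromethyl on an aromatic carbon, para to a large group (methoxy in place of trifluoromethyl on an aromatic carbon). For the measured compounds named here, no step involving methoxy has been measured. Going by the values given here, the only measured step that bears on this change is the exchange of trifluoromethoxy for trifluoromethyl, which gave an at least 1.0-fold lower number from compound 1 to compound 2 (0.02 log units; that floor lies within the scatter) as its size. On the strength of an at least 1.0-fold lower number from compound 1 to compound 2 (0.02 log units; that floor lies within the scatter) alone, no step beyond the scatter is expected in this assay for the new exchange. The expected size is a 1.1-fold higher number from compound 2 to compound 3 (0.03 log units; within the scatter) in this estimate. For compound 3 the estimated value is 500000 nM within a range of 280000 nM to 900000 nM in this assay's terms.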

Compound 3, half-maximal cytotoxic concentration: > 500000 nM
Compound 3 gave a limit, no number; the forecaster's own chance of this, stated with the estimate: 60%; the middle value sits exactly at the limit.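

With methoxy on an aromatic carbon, para to a large group, compound 3 gives > 500000 nM in this assay, and that is a limit of the assay, not a number. Methoxy in place of trifluoromethyl thus shows an at least 1.0-fold higher number from compound 2 to compound 3 (0.02 log units; that floor lies within the scatter), so this position now has a third group with no step beyond the scatter, though the floor does not fix the true size of the step. The step between compound 1 and compound 3 cannot be read, because both values are limits: the limit of > 500000 nM in this assay, at which 2 of the 3 values shown sit.

Going by these compounds, how far compound 1 and compound 3 would lie from compound 2 on a readable scale stays open. Also open, on these data alone, is whether an amine or a carboxylic acid on the same aromatic carbon would give a readable number in this assay.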